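This account rests on a few compounds, and the source may have more. Where it says the series, first, only, none or still open, it means among the compounds named here.

Compound 1 `CCCCOc1ccc(C(CC)NC(=O)Oc2ccccc2F)cc1`: in an assay on H4 cells for inhibition of Fatty-acid amide hydrolase 1 (Homo sapiens) (on this read-out lower numbers stand for stronger inhibition and higher numbers for weaker inhibition), compound 1 gives 7.7 nM
Compound 2 `CCCCOc1ccc(C(CC)NC(=O)Oc2ccc(F)cc2)cc1`: in this assay compound 2 gives 12 nM

Going by the values given here, of these two numbers compound 2 has the higher one, yet the only measured step, a 1.6-fold higher number from compound 1 to compound 2 (0.19 log units; within the scatter), stays within the scatter, so the two compounds cannot be ranked. Compound 3 `CCCCOc1ccc(C(CC)NC(=O)Oc2ccc(OC)cc2)cc1` differs from compound 2 by methoxy in place of fluoro on an aromatic carbon. Among the compounds with values here, no measured step swaps fluoro for methoxy; the one step available only moves a fluoro around the same ring and changed little. With nothing pointing either way, the number for compound 3 is expected to stay close to that of compound 2, and the estimated step of a 1.7-fold higher number from compound 2 to compound 3 (0.22 log units; within the scatter) is expected to remain within the scatter. Compound 3 is estimated at 20 nM, ranging from 6 nM to 70 nM.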

Compound 3, half-maximal inhibitory concentration: 12 nM
Estimate against measurement, compound 3: 1.7-fold (0.22 log units) above; the range from low to high includes it.
By their numbers in this assay, from the lowest: compounds 1, 2 and 3 (each within the scatter of the next).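

On the aromatic carbon para to a large group, methoxy in place of fluoro gives no change at the digits printed from compound 2 to compound 3 (within the scatter) in this assay and so a group of two heavy atoms reads like one of a single heavy atom. Set against the 2-fluorophenyl group, the 4-methoxyphenyl group gives a 1.6-fold higher number from compound 1 to compound 3 (0.19 log units; within the scatter) and so the three groups on this oxygen cannot be ranked. No measured evidence here explains this likeness.

As far as these compounds go, whether an amine or a carboxylic acid at this ring carbon would read the same stays open. So does the outcome with a longer chain on the methoxy oxygen.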